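The source may report more compounds than this note shows. Statements on the series, on what has been measured and on what is new or still open speak of the compounds shown alone.

Compound 2 `O=C(/C=C/c1cc2ccccc2nc1Cl)c1ccc(Br)cc1` gives 468 nM in an assay on nucleic acid for binding affinity to Calf thymus DNA (Bos taurus) (on this read-out lower numbers stand for stronger inhibition and higher numbers for weaker inhibition), and of the two numbers shown it and compound 1 `O=C(/C=C/c1cc2ccccc2nc1Cl)c1ccc(Cl)cc1`, which gives 562 nM, lie within the scatter of each other. Within the data shown here, the only measured step, a 1.2-fold lower number from compound 1 to compound 2 (0.08 log units; within the scatter), changed nothing beyond the scatter. Compound 3 `O=C(/C=C/c1cc2ccccc2nc1Cl)c1ccc([N+](=O)[O-])cc1` has a nitro in place of bromo on an aromatic carbon. Among the measured compounds shown here, no measured step involves a nitro, so that single step is only a weak guide, and no change beyond the scatter is expected in this assay. Compound 3 is therefore estimated at 500 nM, with a range from 150 nM to 1700 nM. The step this expectation means is a 1.1-fold higher number from compound 2 to compound 3 (0.03 log units; within the scatter).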

Compound 3, inhibition constant: 531 nM
The estimate for compound 3 lay 1.1-fold (0.03 log units) below the measured number, and the stated range covers the measured number.
By their numbers in this assay, from the lowest: compounds 2, 3 and 1 (each within the scatter of the next).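

Replacing either halogen with nitro, a larger group with hydrogen-bond acceptors, still changes nothing beyond the scatter in this assay: the steps are a 1.1-fold higher number from compound 2 to compound 3 (0.05 log units; within the scatter) and a 1.1-fold lower number from compound 1 to compound 3 (0.02 log units; within the scatter). So at this place on the ring, para to a large group, the number holds for a group that is not a halogen as well as for the two halogens. No measurement shown here offers an explanation for this. Still open, as far as these compounds go, is whether an amine, a carboxylic acid or a longer chain at this place would move the number beyond the scatter.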